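The source may hold more compounds than are shown below. What is called first, only, known or untested is meant among the compounds shown, and "the series" means these compounds.

Values in a functional assay on MDA-MB-468 cells (Homo sapiens) for antiproliferative activity; a higher number here means a weaker inhibitor of growth, a lower number a stronger inhibitor of growth:
- compound 1 `COc1ccc(-c2nc3ccccc3s2)cc1OC`: 530 nM
- compound 2 `COc1ccc(-c2nc3cc(F)ccc3s2)cc1F`: 640 nM
- compound 3 `COc1cc(-c2nc3cc(F)ccc3s2)cc(OC)c1OC`: 2.1 nM

Compound 2 at 640 nM and compound 1 at 530 nM lie within the usual scatter of each other. Compound 3 gives 2.1 nM, a far lower number and well beyond that scatter.

The next compound is compound 4 `CCOc1cc(-c2nc3cc(F)ccc3s2)ccc1OC`, which has ethoxy in place of fluoro on an aromatic carbon, ortho to a methoxy group and meta to a large group: ethoxy in place of fluoro on an aromatic carbon.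

Among the measured compounds shown here, no pair of measured compounds differs in just one place, so there is no direct precedent for this change. Compound 3 at 2.1 nM suggests that a lower number is possible, as it has methoxy where compound 2 has fluoro. Compound 1 at 530 nM is a caution, since it also has methoxy there yet its number is not low.

The expected size of the step of a 16-fold lower number from compound 2 to compound 4 (1.20 log units; beyond the scatter) is a clear fall, beyond the scatter, though this estimate is uncertain. For compound 4 the estimated value is 40 nM, with an expected range of 2 nM to 600 nM.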

Compound 4, concentration for 50% growth inhibition: 92 nM
The estimate for compound 4 lay 2.3-fold (0.36 log units) below the measured number, and the stated range covers the measured number.
By their numbers in this assay, from the lowest: compound 3; then compound 4; then compounds 1 and 2 (each within the scatter of the next).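

In this assay, among the compounds shown here, putting ethoxy in place of fluoro on an aromatic carbon, ortho to a methoxy group and meta to a large group, gives a 7.0-fold lower number from compound 2 to compound 4 (0.84 log units; beyond the scatter) as the first direct comparison at this position. The position therefore takes ethoxy, with 3 heavy atoms and a hydrogen-bond acceptor, in place of the single fluorine atom, and growth inhibition becomes stronger rather than being lost. No measurement shown here explains why the number falls with this change. As far as these compounds go, whether a longer chain such as propoxy, or an amine, at this position would lower the number further remains open. For the compounds shown here, with only this one step, it is also unclear how much of the fall goes with the oxygen and how much with the carbons of the ethoxy group.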